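This account rests on a few compounds, and the source may have more. Where it says the series, first, only, none or still open, it means among the compounds named here.

Values in a functional assay on U-937 cells (Homo sapiens) for cytotoxicity, read by MTT assay, with a stated time of 3 days; on this read-out higher numbers stand for weaker inhibition and lower numbers for stronger inhibition:
- compound 1 `N#Cc1c(O)nc(SCc2nc3ccccc3[nH]2)nc1-c1ccccc1`: 3.28 nM
- compound 2 `CCNc1nc(SCc2nc3ccccc3[nH]2)nc(-c2ccccc2)c1C#N`: 2.63 nM

Compound 2 holds the lowest of these two numbers, but a 1.2-fold lower number from compound 1 to compound 2 (0.10 log units; within the scatter) leaves it level with compound 1. Compound 3 `N#Cc1c(Nc2ccccn2)nc(SCc2nc3ccccc3[nH]2)nc1-c1ccccc1` follows from compound 2 with pyridin-2-yl in place of ethyl on a nitrogen on an aromatic ring. Among the compounds with values here, no measured step changes this group. The nearest evidence is the swap on the same aromatic carbon, a 1.2-fold lower number from compound 1 to compound 2 (0.10 log units; within the scatter). In this assay, no shift beyond the scatter is therefore expected, with the estimated change being a 1.1-fold higher number from compound 2 to compound 3 (0.06 log units; within the scatter). For compound 3 the estimate is 3 nM, with an expected range of 1 nM to 9 nM.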

Compound 3, half-maximal inhibitory concentration: 2.55 nM
Compound 3: the middle estimate sits 1.2-fold (0.07 log units) above what was measured; the measured number falls inside the stated range.
By their numbers in this assay, from the lowest: compounds 3, 2 and 1 (each within the scatter of the next).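

In this assay, the aromatic carbon bearing the variable group shows no sensitivity to a ring on the amine nitrogen: pyridin-2-yl in place of ethyl gives a 1.0-fold lower number from compound 2 to compound 3 (0.01 log units; within the scatter) and remains within the scatter. (Pyridin-2-yl)amino in place of hydroxy gives a 1.3-fold lower number from compound 1 to compound 3 (0.11 log units; within the scatter) and also remains within the scatter, so all three groups on this carbon are level. Nothing on hand accounts for this flat response.

On these data alone, whether a morpholine or a carboxylic acid at this place would move the number beyond the scatter remains open. So does the effect of a carboxamide in place of the nitrile.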